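Methoxy to Fluoro: A Small Change in a Weak Pair

The source may hold more compounds than are shown below. What is called first, only, known or untested is meant among the compounds shown, and "the series" means these compounds.

Two compounds sharing a common core have been examined in a functional assay on CCRF-CEM cells (Homo sapiens); a higher number here means a weaker inhibitor, a lower number a stronger inhibitor. Compound 1 `OC[C@H]1O[C@@H](n2cc(-c3ccccn3)nn2)[C@H](O)[C@@H]1O` gives 245000 nM in this assay. Compound 2 `COc1ccc(-c2cn([C@@H]3O[C@H](CO)[C@@H](O)[C@H]3O)nn2)cc1` gives 73000 nM in this assay, the lower of the two numbers, and compound 1 stands at a higher number, a gap beyond the scatter. Compound 3 `OC[C@H]1O[C@@H](n2cc(-c3ccc(F)cc3)nn2)[C@H](O)[C@@H]1O` has not yet been measured. It differs from compound 2 by fluoro in place of methoxy on an aromatic carbon. Among the compounds with values here, no step between measured compounds covers this exchange, so the pair offers no direct precedent. The step of a 1.4-fold higher number from compound 2 to compound 3 (0.14 log units; within the scatter) is expected to be small, if anything toward a slightly weaker number, and not clearly beyond the scatter, because compound 2 already sits at 73000 nM and the exchange is modest in size. Compound 3 is therefore estimated at 100000 nM, within a range of 40000 nM to 260000 nM.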

Compound 3, half-maximal inhibitory concentration: 217000 nM
Estimate against measurement, compound 3: 2.2-fold (0.34 log units) below; the range from low to high includes it.
By their numbers in this assay, from the lowest: compound 2; then compounds 3 and 1 (each within the scatter of the next).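

In this assay, within the data shown here, fluoro in place of methoxy on this aromatic carbon, para to a large group, gives a 3.0-fold higher number from compound 2 to compound 3 (0.47 log units; beyond the scatter) and so provides the first direct reading of this exchange: the position does respond to it. The other new step, 4-fluorophenyl in place of pyridin-2-yl, is a 1.1-fold lower number from compound 1 to compound 3 (0.05 log units; within the scatter) and does not separate these two groups at this end of the shared core. Nothing measured on these compounds accounts for either step.

From the compounds shown here alone, it remains open whether a hydroxyl, an amine or an ethoxy group at this position would keep, improve on or lose the number of compound 2 (73000 nM). The compounds shown also leave open whether methoxy on the pyridin-2-yl ring of compound 1 would bring a similar step.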